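Acetoxy for Amino: Expected Loss of Hepatocyte Stability

This account rests on a few compounds, and the source may have more. Where it says the series, first, only, none or still open, it means among the compounds named here.

Measured compounds:
compound 1 `NC1CCC(CN2CCN(c3cc(=O)c4cc(C(F)(F)F)cc([N+](=O)[O-])c4s3)CC2)CC1` 83.6%
compound 2 `O=C(NC1CCC(CN2CCN(c3cc(=O)c4cc(C(F)(F)F)cc([N+](=O)[O-])c4s3)CC2)CC1)c1ccccc1` 92.9%
compound 3 `O=C(OC1CCC(CN2CCN(c3cc(=O)c4cc(C(F)(F)F)cc([N+](=O)[O-])c4s3)CC2)CC1)c1ccncc1` 1%

In an ADME assay on cells (Hepatocyte, Homo sapiens) for metabolic stability, with a stated time of 30 min (a higher number here means that more of the compound is left, a lower number that less of the compound is left), compound 1 stands second highest of the three; the step of a number 9.3 percentage points higher from compound 1 to compound 2 (within the scatter) is within the scatter, whereas a number 82.6 percentage points lower from compound 1 to compound 3 (beyond the scatter) is large. Compound 4 `CC(=O)OC1CCC(CN2CCN(c3cc(=O)c4cc(C(F)(F)F)cc([N+](=O)[O-])c4s3)CC2)CC1` carries acetoxy in place of amino on a saturated ring carbon. The step that bears on it most is a number 82.6 percentage points lower from compound 1 to compound 3 (beyond the scatter), where an oxygen-linked carbonyl group likewise replaced the amino group; a number 91.9 percentage points lower from compound 2 to compound 3 (beyond the scatter) points the same way. A large downward step is therefore expected in this assay, a number 68.6 percentage points lower from compound 1 to compound 4 (beyond the scatter), though the acetoxy group is smaller than the ((pyridin-4-yl)carbonyl)oxy group and the drop may be less complete. Compound 4 is estimated at 15%, with a range of 1% to 50%.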

Compound 4, percent of the compound remaining: 0%
Compound 4: the middle estimate sits 15 percentage points above what was measured, outside the stated range (below it).
By their numbers in this assay, from the lowest: compounds 4 and 3 (each within the scatter of the next); then compounds 1 and 2 (each within the scatter of the next).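

In this assay the acetoxy group on the saturated ring carbon gives a number 83.6 percentage points lower from compound 1 to compound 4 (beyond the scatter) and a number 92.9 percentage points lower from compound 2 to compound 4 (beyond the scatter) as well, so among these compounds the low numbers go with both oxygen-linked carbonyl groups and do not require the pyridin-4-yl group. A step of a number 1 percentage points lower from compound 3 to compound 4 (within the scatter) leaves methyl and pyridin-4-yl on the carbonyl carbon indistinguishable here. Nothing available explains this loss. The compounds shown leave open how a hydroxy group, a methoxy group or a carbamate on this ring carbon would stand in this assay.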